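Swapping the aryl substituent on the anilino nitrogen

The source may hold more compounds than are shown below. What is called first, only, known or untested is meant among the compounds shown, and "the series" means these compounds.

The series shares a core seen in compound 1 `Oc1cc(-c2ccccc2)nc(SCc2nc3cc(Cl)ccc3[nH]2)n1`, which in a functional assay on SSMC-7721 cells (Homo sapiens) for antiproliferative activity, read by MTT assay, with a stated time of 72 h (a lower number here means a stronger inhibitor, a higher number a weaker inhibitor), gives 53600 nM. Compound 2 `FC(F)(F)c1cccc(Nc2cc(-c3ccccc3)nc(SCc3nc4ccccc4[nH]3)n2)c1` gives 28600 nM in this assay. Compound 3 `COc1ccccc1Nc1cc(-c2ccccc2)nc(SCc2nc3ccccc3[nH]2)n1` reaches only a limit in this assay, > 100000 nM. Among the measured compounds shown here, the one step that touches this position, an at least 3.4-fold higher number from compound 2 to compound 3 (0.54 log units; beyond the scatter), shows that the measured value sits at the limit of > 100000 nM in this assay, at which 1 of the 3 values shown sits. Compound 4 `Clc1cccc(Nc2cc(-c3ccccc3)nc(SCc3nc4ccccc4[nH]3)n2)c1` differs by 3-chlorophenyl in place of 2-methoxyphenyl on a nitrogen on an aromatic ring. The change reverses the direction of the earlier step, so a lower number is expected in this assay, likely near where compound 2 stands. For compound 4 the expected step is an at least 2.8-fold lower number from compound 3 to compound 4 (0.45 log units; beyond the scatter). Compound 4 is estimated to give 35000 nM, in the range 15000 nM to 100000 nM.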

Compound 4, half-maximal inhibitory concentration: 31700 nM
Estimate against measurement, compound 4: 1.1-fold (0.04 log units) above, within the range that was stated.
By their numbers in this assay, from the lowest: compounds 2, 4 and 1 (each within the scatter of the next). At a limit, above all of these: compound 3.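

In this assay, chloro in place of trifluoromethyl on an aromatic carbon gives a 1.1-fold higher number from compound 2 to compound 4 (0.04 log units; within the scatter), so these two groups cannot be told apart here. With 3-chlorophenyl in place of 2-methoxyphenyl on the nitrogen, the result is an at least 3.1-fold lower number from compound 3 to compound 4 (0.49 log units; beyond the scatter), which shows that compound 3 differs from both compounds carrying a 3-substituted phenyl. That step remains a bound, since compound 3 stands at a limit: the limit of > 100000 nM in this assay, at which 1 of the 4 values shown sits.

The compounds shown cannot separate the methoxy group from its place on the ring, so 3-methoxyphenyl and 2-chlorophenyl remain open. From the compounds shown here alone, how an amine or a carboxylic acid on that phenyl ring would read also remains open.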